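The source may report more compounds than this note shows. Statements on the series, on what has been measured and on what is new or still open speak of the compounds shown alone.

Measured so far:
compound 1 `C[C@H](NC(=O)CN(c1nc(Cl)nc2[nH]cnc12)C1CC1)C(=O)O` in a functional assay on the whole organism (Tail, strain ICR) with Mus musculus as the target, in the tail flick test, with a stated time of 30 min, at a dose of 25 umol/kg by the oral route (a lower number here means a weaker effect, a higher number a stronger effect of the compound at the dose given), gives 48.1%
compound 2 `NC(=O)C[C@H](NC(=O)CN(c1nc(Cl)nc2[nH]cnc12)C1CC1)C(=O)OCc1ccccc1` in this assay gives 24.4%

Compound 2 holds the lower of the two numbers, sitting beyond the scatter under compound 1. Compound 3 `NC(=O)C[C@H](NC(=O)CN(c1nc(Cl)nc2[nH]cnc12)C1CC1)C(=O)O` is not yet measured. It differs from compound 2 by hydrogen in place of benzyl on an oxygen next to a carbonyl group. Among the measured compounds shown here, no step between measured compounds is known, so the size of this change in this assay is open; a rise rather than a fall is expected because compound 1, which also carries the carboxy, gives 48.1%. Compound 3 is expected to give 40%, between 20% and 60%. The expected step is a number 15.6 percentage points higher from compound 2 to compound 3 (beyond the scatter).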

Compound 3, a percentage reported as activity, at one dose (the size of the read-out at that dose, not a potency): 29.7%
Estimate against measurement, compound 3: 10.3 percentage points above, within the range that was stated.
By their numbers in this assay, from the lowest: compounds 2 and 3 (each within the scatter of the next); then compound 1.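

In this assay, hydrogen in place of benzyl on an oxygen next to a carbonyl group gives a number 5.3 percentage points higher from compound 2 to compound 3 (within the scatter), so benzyloxycarbonyl and carboxy are not separated at this position. The larger difference lies at the saturated chain carbon, where carbamoyl in place of hydrogen gives a number 18.4 percentage points lower from compound 1 to compound 3 (beyond the scatter). Nothing measured accounts for either step.

Open, going by these compounds, is how an amine or a longer chain in place of carbamoyl would read at that carbon. Also open, on these data alone, is whether an ethyl ester would match benzyloxycarbonyl or carboxy.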